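Aryl swap on compound 1: expectation for compound 4

The source may hold more compounds than are shown below. What is called first, only, known or untested is meant among the compounds shown, and "the series" means these compounds.

In a functional assay on U-87MG ATCC cells (Homo sapiens) for cytotoxicity, read by MTT assay, with a stated time of 72 h (a higher number here means a weaker inhibitor, a lower number a stronger inhibitor), compound 1 `CN(C)CCn1cnnc1-c1cc(Oc2ccc(NC(=O)N/N=C/c3ccccc3O[N+](=O)[O-])cc2F)ccn1` gives 7150 nM, the highest of the two plain numbers obtained in this series. Compound 2 `CN(C)CCn1cnnc1-c1cc(Oc2ccc(NC(=O)N/N=C/c3cccc(Br)c3)cc2F)ccn1` gives 830 nM in this assay, and the step of an 8.6-fold lower number from compound 1 to compound 2 (0.94 log units; beyond the scatter) is modest. Compound 3 `CN(C)CCn1cnnc1-c1cc(Oc2ccc(NC(=O)N/N=C/c3cc(Br)c(O)c(Br)c3)cc2F)ccn1` returns only a limit of the assay, > 100000 nM, which is the limit of > 100000 nM in this assay, at which 1 of the 3 values shown sits. Against that limit the step of an at least 13-fold higher number from compound 1 to compound 3 (1.14 log units; beyond the scatter) is large, and so is an at least 120-fold higher number from compound 2 to compound 3 (2.08 log units; beyond the scatter).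

Compound 4 `COc1ccc(/C=N/NC(=O)Nc2ccc(Oc3ccnc(-c4nncn4CCN(C)C)c3)c(F)c2)cc1O` has not been measured. It differs from compound 1 at the same position that is varied in compounds 2 and 3: 3-hydroxy-4-methoxyphenyl in place of 2-(nitrooxy)phenyl on a carbon with a double bond to nitrogen. The measured steps show that this aryl group governs the outcome over a wide span, with compound 2 lower and compound 3 beyond the range of this assay; the entering group carries a hydroxy group as compound 3 does, but no bromine. A moderate rise in the number from compound 1 is therefore expected, with wide uncertainty: a 2.1-fold higher number from compound 1 to compound 4 (0.32 log units; beyond the scatter). For compound 4 a value of about 15000 nM is estimated, within the range 3000 nM to 80000 nM.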

Compound 4, half-maximal inhibitory concentration: > 100000 nM
Compound 4 was reported as a limit; the forecaster's own chance of this, stated with the estimate: 20%; middle value at least 6.6-fold (0.82 log units) from the limit.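

In this assay, the change to 3-hydroxy-4-methoxyphenyl on a carbon with a double bond to nitrogen gives an at least 13-fold higher number from compound 1 to compound 4 (1.14 log units; beyond the scatter) and an at least 120-fold higher number from compound 2 to compound 4 (2.08 log units; beyond the scatter), so bromine is not required for a compound in this series to reach the limit. Among the compounds shown, the two whose aryl group carries a hydroxy group sit at that limit, while the two without one give plain numbers, and none goes against this: the limit of > 100000 nM in this assay, at which 2 of the 4 values shown sit. The step from compound 3 to compound 4 cannot be read, as both values are limits.

The compounds shown do not separate the hydroxy group from the methoxy group or the bromines that accompany it. An aryl group carrying methoxy alone, or an amine in place of the hydroxy group, would test whether the hydroxy group is what matters here.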